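Urea series at a vanilloid-type cation channel: isoquinoline isomer

The source may report more compounds than this note shows. Statements on the series, on what has been measured and on what is new or still open speak of the compounds shown alone.

Measured compounds:
compound 1 `CN(C)C1(Cc2ccccc2)CCN(c2cc(C(F)(F)F)ccc2CNC(=O)Nc2ccc(NS(C)(=O)=O)c(F)c2)CC1` — "not active" (no number reported)
compound 2 `CN(C)C1(Cc2ccccc2)CCN(c2cc(C(F)(F)F)ccc2CNC(=O)Nc2cccc3c(=O)[nH]ccc23)CC1` — 43.7 nM
compound 3 `CN(C)C1(Cc2ccccc2)CCN(c2cc(C(F)(F)F)ccc2CNC(=O)Nc2ccc3cnccc3c2)CC1` — "not active" (no number reported)

In an assay on CHO cells for agonist activity at transient receptor potential cation channel subfamily V member 1 (Homo sapiens), read by scintillation counting, with a stated time of 5 min, in the presence of a further agent that is not named here (on this read-out lower numbers stand for an effect already at smaller amounts and higher numbers for an effect only at larger amounts of compound), only compound 2 gives a number, 43.7 nM. Compound 1 is reported as "not active" (no number reported) without a number. Compound 3 likewise stands as "not active" (no number reported), so it has no value to rank against compound 2; it shares the no-number outcome with compound 1, and nothing more can be read from these three entries.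

Compound 4 `CN(C)C1(Cc2ccccc2)CCN(c2cc(C(F)(F)F)ccc2CNC(=O)Nc2cccc3cnccc23)CC1` differs from compound 3 only by isoquinolin-5-yl in place of isoquinolin-6-yl on an amide-type nitrogen; the atom count is unchanged and the atoms are joined differently. Among the measured compounds shown here, no measured pair in this set shows what such a rearrangement on the urea nitrogen does in this assay, so no size or direction for the step can be stated; the sole number belongs to compound 2, and compound 3 itself gives none. The expectation for compound 4 is therefore wide, with a real chance of another no-number report. Compound 4 is estimated at 300 nM, between 40 nM and 3000 nM.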

Compound 4, half-maximal effective concentration: "not active" (no number reported)
Nothing numeric was reported for compound 4; the estimate stays without a comparison.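

In this assay compound 3 and compound 4 both stand without a number, so no step can be read for isoquinolin-5-yl against isoquinolin-6-yl. No available evidence bears on this shared outcome. The compounds shown leave open whether this rearrangement affects activity at all.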